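Nitro to chloro on the benzyl ring: a second test

This account rests on a few compounds, and the source may have more. Where it says the series, first, only, none or still open, it means among the compounds named here.

Measured compounds:
compound 1 `O=[N+]([O-])c1ccc(Cn2cc(COc3cccc([N+](=O)[O-])c3)nn2)cc1` gives 17.1 ug/mL
compound 2 `O=[N+]([O-])c1cccc(OCc2cn(Cc3ccc(Cl)cc3)nn2)c1` gives 37.3 ug/mL
compound 3 `Cc1cc(OCc2cn(Cc3ccc([N+](=O)[O-])cc3)nn2)ccc1Cl` gives 13.4 ug/mL

All three numbers come from a physicochemical assay, read by spectrophotometry, with a stated time of 30 min; a higher number here means a weaker inhibitor, a lower number a stronger inhibitor. Compound 1 and compound 2 share one core and differ in a single place: chloro in place of nitro on an aromatic carbon. That change brought a 2.2-fold higher number from compound 1 to compound 2 (0.34 log units; beyond the scatter), a step that lies beyond the usual scatter of this assay.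

Compound 3 stands on a different core; how its core differs from that of compound 1 is not broken down here. Its value sits within the scatter of compound 1, so the two cannot be ordered, while compound 2 gives a clearly higher number than either.

Compound 4 `Cc1cc(OCc2cn(Cc3ccc(Cl)cc3)nn2)ccc1Cl` has not yet been measured. It differs from compound 3 in exactly one place: chloro in place of nitro on an aromatic carbon. This is the same change, at the same kind of place, as the one already made between compound 1 and compound 2, and it occurs twice among the compounds shown.

Within the data shown here, on that single precedent, the step from compound 3 to compound 4 is expected to resemble the earlier one, roughly a 2.2-fold higher number from compound 3 to compound 4 (0.34 log units; beyond the scatter), because the only measured instance of this change gave a 2.2-fold higher number from compound 1 to compound 2 (0.34 log units; beyond the scatter). With one example behind it, the expectation is held loosely. Compound 4 is thus estimated at 29 ug/mL, with a plausible range from 15 ug/mL to 55 ug/mL.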

Compound 4, half-maximal inhibitory concentration: 11.4 ug/mL
For compound 4 the middle estimate is 2.5-fold (0.41 log units) above the measured one; the whole stated range lies above it.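

Carried to the core of compound 3 in this assay, the replacement of nitro by chloro gave a 1.2-fold lower number from compound 3 to compound 4 (0.07 log units; within the scatter) and so left the two compounds unordered, whereas the same replacement on the core of compound 1 had given a 2.2-fold higher number from compound 1 to compound 2 (0.34 log units; beyond the scatter) and there separated the pair. This shows that, in this series, a step measured on one core did not hold on the other, even though the group that leaves, the group that enters and the kind of aromatic carbon involved were the same in both pairs; one core's result was therefore a poor guide to the other's. It does not show which of the differences between the two cores matters, or that either step is the typical one for this replacement, and no measurement shown here accounts for the contrast between the two pairs.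

Going by these compounds, with only two instances, on two cores, it remains open how this replacement behaves on any further core. On these data alone, it also remains open whether an amine or a carboxylic acid in place of the nitro group would follow either step, or neither.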